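A few compounds are considered here, and "the series" means these few. Any claim that something is new, unique, unknown or untested is made for them only; others in the source may bear on it.

Working notes on the series, cytotoxicity arm.

Compound 1 `CCC1(Cc2ccccc2)OS(=O)(=O)C=C1OCc1cccc(Cl)c1` gives 50000 nM in an ADME assay on HEL cells (Homo sapiens) for cytotoxicity, with a stated time of 3 days; a lower number here means that less compound is tolerated, a higher number that more compound is tolerated. Compound 2 `C=CCOC1=CS(=O)(=O)OC1(CC)Cc1ccccc1` reaches only the limit of this assay, > 200000 nM, which is a limit and not a number (the limit of > 200000 nM in this assay, at which 1 of the 3 values shown sits). Compound 3 `CCC1(Cc2ccccc2)OS(=O)(=O)C=C1OCc1ccc(Br)cc1` gives 171000 nM in this assay. Among the two plain numbers, compound 3 holds the higher one, and the nearest is compound 1, with a 3.4-fold higher number from compound 1 to compound 3 (0.53 log units; beyond the scatter); the other value shown is a limit.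

Compound 4 `CCC1(Cc2ccccc2)OS(=O)(=O)C=C1OCCc1ccccc1` differs from compound 3 by benzyl in place of 4-bromophenyl on a saturated chain carbon bound to an oxygen on an unsaturated carbon. The measured steps that bear on this exchange are those that swap the group on that same saturated chain carbon: a 3.4-fold higher number from compound 1 to compound 3 (0.53 log units; beyond the scatter) and an at least 1.1-fold lower number from compound 2 to compound 3 (0.06 log units; that floor lies within the scatter), the first modest and the second within the scatter. Both suggest that changing the group at this position moves the tolerated concentration little, or only modestly, so the expected step of a 1.1-fold lower number from compound 3 to compound 4 (0.06 log units; within the scatter) is taken as small. Compound 4 is therefore estimated at 150000 nM in this assay, with a range from 60000 nM to 400000 nM.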

Compound 4, half-maximal cytotoxic concentration: 48000 nM
Beside the measured number, compound 4's estimate is 3.1-fold (0.49 log units) above it, outside the stated range (below it).
By their numbers in this assay, from the lowest: compounds 4 and 1 (each within the scatter of the next); then compound 3. At a limit, above all of these: compound 2.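

In this assay, the exchange gives a 3.6-fold lower number from compound 3 to compound 4 (0.55 log units; beyond the scatter), so 4-bromophenyl and benzyl are not interchangeable on a saturated chain carbon bound to an oxygen on an unsaturated carbon, although each carries one six-membered aromatic ring of carbon only. Benzyl and 3-chlorophenyl at this place cannot be told apart, with a 1.0-fold lower number from compound 1 to compound 4 (0.02 log units; within the scatter), which leaves compound 3 clear of both other plain numbers. Vinyl to benzyl reads as an at least 4.1-fold lower number from compound 2 to compound 4 (0.61 log units; beyond the scatter), a floor that rests on a limit and not a number: the limit of > 200000 nM in this assay, at which 1 of the 4 values shown sits.

Open, going by these compounds, is whether the higher number of compound 3 follows the bromine or the place of the halogen on the ring, which a 4-chlorophenyl or 3-bromophenyl group at this place would separate. Also open, on these data alone, is how an unsubstituted phenyl, an amine or a carboxylic acid would read here.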